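Notes on the step from compound 2 to compound 4

The source may hold more compounds than are shown below. What is called first, only, known or untested is meant among the compounds shown, and "the series" means these compounds.

The series shares one core, seen in compound 1 `COc1ccc(C(=O)/C=C/c2cc(OC)c(OC)c(OC)c2)c2c1C=CC(C)(C)O2`, compound 2 `COc1ccc(C(=O)/C=C/c2cccc(F)c2)c2c1C=CC(C)(C)O2` and compound 3 `COc1ccc(C(=O)/C=C/c2ccc(OC)c(OC)c2OC)c2c1C=CC(C)(C)O2`, which differ only in the group on the double-bonded chain carbon. All three were tested in a functional assay on HepG2 cells (Homo sapiens) for antiproliferative activity, read by MTT assay, with a stated time of 24 h; on this read-out lower numbers stand for stronger inhibition and higher numbers for weaker inhibition. In this assay compound 1 reaches only the limit of the assay, > 10000 nM. In this assay compound 2 likewise gives only a limit, > 10000 nM. In this assay compound 3 also returns a limit, > 10000 nM. Compound 2 therefore stands where every value shown stands: at the limit of > 10000 nM in this assay, at which 3 of the 3 values shown sit. Among the measured compounds shown here, no step between measured compounds can be sized from this set, since none of the three values is a number.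

The unmeasured compound 4 `COc1ccc(C(=O)/C=C/c2ccccc2Cl)c2c1C=CC(C)(C)O2` differs from compound 2 in one place: 2-chlorophenyl in place of 3-fluorophenyl on a double-bonded chain carbon bound to a double-bonded chain carbon. The measured set gives no indication of how this change acts in this assay, and the three limits give no direction. The expectation is that the step that the limit leaves unreadable from compound 2 to compound 4 is none beyond the scatter, and most likely that compound 4 again returns only a limit. For compound 4 in this assay the estimate is 15000 nM, within 5000 nM to 50000 nM, with a strong chance that only a limit is reported.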

Compound 4, half-maximal inhibitory concentration: > 10000 nM
Compound 4: only a limit was reported; the forecaster's own chance of this, stated with the estimate: 80%; the middle value does not contradict the limit.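

In this assay compound 4 returns only a limit, > 10000 nM. Compound 2 is also a limit, so no step can be read between compound 2 and compound 4. What stays open is how the groups on the chain of the compounds shown would rank in this assay, as all values sit at one point: the limit of > 10000 nM in this assay, at which 4 of the 4 values shown sit.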